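This account rests on a few compounds, and the source may have more. Where it says the series, first, only, none or still open, it means among the compounds named here.

Of the compounds shown here, three built on one shared core have so far been tested in a functional assay on B16 cells (Mus musculus) for cytotoxicity, read by MTT assay, with a stated time of 72 h; a higher number here means a weaker inhibitor, a lower number a stronger inhibitor. Compound 2 `COc1ccc(C(=O)c2cc(OC)c(OC)c(OC)c2)cc1NC(=O)/C=C/c1ccc(OC)c(OC)c1` gives 6300 nM, the highest of the three numbers. Compound 1 `COc1ccc(C(=O)c2cc(OC)c(OC)c(OC)c2)cc1NC(=O)/C=C/c1cc(OC)c(OC)c(OC)c1` gives 1200 nM, and the step of a 5.3-fold higher number from compound 1 to compound 2 (0.72 log units; beyond the scatter) comes from a hydrogen in place of a methoxy on an aromatic carbon. Compound 3 `COc1ccc(C(=O)c2cc(OC)c(OC)c(OC)c2)cc1NC(=O)/C=C/c1ccc(F)cc1` gives 400 nM, the lowest number of the set. Compound 4 `COc1ccc(C(=O)c2cc(OC)c(OC)c(OC)c2)cc1NC(=O)/C=C/c1cccc(OC(F)(F)F)c1` has not yet been measured. It differs from compound 2 by 3-(trifluoromethoxy)phenyl in place of 3,4-dimethoxyphenyl on a double-bonded chain carbon bound to a double-bonded chain carbon. For the measured compounds named here, two measured steps bear on this change: a 16-fold lower number from compound 2 to compound 3 (1.20 log units; beyond the scatter) and a 3.0-fold lower number from compound 1 to compound 3 (0.48 log units; beyond the scatter), both of which replace a methoxy-bearing phenyl on that chain carbon with 4-fluorophenyl and both of which lower the number. The change leading to compound 4 also removes the 3,4-dimethoxyphenyl, so a lower number than that of compound 2 is expected in this assay. The entering 3-(trifluoromethoxy)phenyl has not itself been tested here, so the size of the step is uncertain. Compound 4 is expected to give about 900 nM, with a range from 250 nM to 3000 nM. The expected step is a 7.0-fold lower number from compound 2 to compound 4 (0.85 log units; beyond the scatter).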

Compound 4, half-maximal inhibitory concentration: 6300 nM
Beside the measured number, compound 4's estimate is 7.0-fold (0.85 log units) below it, outside the stated range (above it).
By their numbers in this assay, from the lowest: compound 3; then compound 1; then compounds 2 and 4 (each within the scatter of the next).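

In this assay, taking a methoxy-bearing phenyl off this chain carbon does not by itself lower the number: 3-(trifluoromethoxy)phenyl in place of 3,4-dimethoxyphenyl gives no change at the digits printed from compound 2 to compound 4 (within the scatter), so the loss of those methoxy groups alone does not account for the low number of compound 3. Fluorine on this phenyl does not guarantee a low number either, as 3-(trifluoromethoxy)phenyl in place of 4-fluorophenyl gives a 16-fold higher number from compound 3 to compound 4 (1.20 log units; beyond the scatter), and in place of 3,4,5-trimethoxyphenyl it gives a 5.3-fold higher number from compound 1 to compound 4 (0.72 log units; beyond the scatter). Nothing available here explains why these groups differ.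

Going by these compounds, whether the low number of compound 3 is tied to the fluorine or to the 4-fluorophenyl group as a whole stays open. Also open, on these data alone, is how a phenyl carrying a chlorine, an amine or a carboxylic acid would read at this chain carbon.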